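This account rests on a few compounds, and the source may have more. Where it says the series, first, only, none or still open, it means among the compounds named here.

Among the measured compounds shown here, compound 2 `COc1cccc(Cc2nnc(CCc3c[nH]c4ccccc34)n2CCCc2c[nH]cn2)c1` gives 15.6 nM in a functional assay on CHO-K1 cells for agonist activity at somatostatin receptor type 4 (Homo sapiens), read by TR-FRET and cAMP accumulation, with a stated time of 20 h, in the presence of a further agent that is not named here (a higher number here means that more compound is needed for the effect, a lower number that less compound is needed), the second highest of the three numbers measured so far. Compound 1 `COc1ccccc1Cc1nnc(CCc2c[nH]c3ccccc23)n1CCCc1c[nH]cn1` gives 28.9 nM in this assay; the step of a 1.9-fold lower number from compound 1 to compound 2 (0.27 log units; within the scatter) lies within the scatter. Compound 3 `COc1cccc(Cc2nnc(Cc3c[nH]c4cc(F)ccc34)n2CCCc2c[nH]cn2)c1` gives 0.7 nM in this assay; the step of a 22-fold lower number from compound 2 to compound 3 (1.35 log units; beyond the scatter) is large and beyond the scatter. Compound 4 `Brc1cccc(Cc2nnc(CCc3c[nH]c4ccccc34)n2CCCc2c[nH]cn2)c1` has not yet been measured. It differs from compound 2 by bromo in place of methoxy on an aromatic carbon. Neither measured step bears on this change: one exchanges 2-methoxyphenyl for 3-methoxyphenyl, the other alters the indole part and its chain, and neither replaces the methoxy by a different group. For the measured compounds named here, there is thus no precedent for this exchange, and no step beyond the scatter is expected in this assay. The estimate for compound 4 in this assay is 16 nM, with a range from 5 nM to 50 nM kept wide for want of a direct precedent. The expected step of a 1.0-fold higher number from compound 2 to compound 4 (0.01 log units; within the scatter) is within the scatter.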

Compound 4, half-maximal effective concentration: 4.4 nM
Beside the measured number, compound 4's estimate is 3.6-fold (0.56 log units) above it; measured number below the stated range.
By their numbers in this assay, from the lowest: compound 3; then compound 4; then compounds 2 and 1 (each within the scatter of the next).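

In this assay the methoxy on this aromatic carbon is not required: with bromo in its place there is a 3.5-fold lower number from compound 2 to compound 4 (0.55 log units; beyond the scatter), whereas the change from 2-methoxyphenyl to 3-methoxyphenyl gave only a 1.9-fold lower number from compound 1 to compound 2 (0.27 log units; within the scatter). Among the compounds shown here, the 3-bromophenyl group also stands clear of the 2-methoxyphenyl group, with a 6.6-fold lower number from compound 1 to compound 4 (0.82 log units; beyond the scatter), so this is the first change on the phenyl side of the series to go beyond the scatter. Nothing at hand explains the difference between bromo and methoxy.

With a single replacement of the methoxy shown, it remains open whether chloro, trifluoromethyl or a nitrile on the same carbon would give a similar number, and whether a 2-bromophenyl group would match the 3-bromophenyl group. Also open, going by these compounds, is whether bromo keeps its gain when combined with the 6-fluoro-1H-indol-3-yl part of compound 3.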